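The source may hold more compounds than are shown below. What is called first, only, known or untested is meant among the compounds shown, and "the series" means these compounds.

Compound 1: `Cc1cc(C)c(S(=O)(=O)N2CCC(N3CCC(O)CC3)CC2)c(C)c1` — 106 nM
Compound 2: `Cc1cc(C)c(S(=O)(=O)N2CCC(N3CCC(CCO)CC3)CC2)c(C)c1` — 19 nM
Compound 3: `Cc1cc(C)c(S(=O)(=O)N2CCC(N3CCC(c4ccccc4)CC3)CC2)c(C)c1` — 865 nM

These three compounds share a core and differ only in the group on a saturated ring carbon of the six-membered ring attached to the second ring nitrogen. In a functional assay on DLD-1 cells (Homo sapiens) for antiproliferative activity, read by CellTiter-Glo, with a stated time of 72 h (on this read-out higher numbers stand for weaker inhibition and lower numbers for stronger inhibition), compound 2 gives 19 nM, the lowest of the three numbers shown; the nearest is compound 1 with 106 nM, and the furthest is compound 3 with 865 nM. The step of a 5.6-fold lower number from compound 1 to compound 2 (0.75 log units; beyond the scatter) and the step of a 46-fold higher number from compound 2 to compound 3 (1.66 log units; beyond the scatter) both lie beyond the scatter.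

Compound 4, `Cc1cc(C)c(S(=O)(=O)N2CCC(N3CCC(C)OC3)CC2)c(C)c1`, has not been measured in this assay. It differs from compound 2 as follows: a group of 7 heavy atoms (5 carbon, 1 nitrogen, 1 oxygen; one six-membered non-aromatic ring with 2 hetero atoms) in place of a group of 9 heavy atoms (7 carbon, 1 nitrogen, 1 oxygen; one six-membered non-aromatic ring with 1 hetero atom), on a saturated ring carbon. The entering group has no hydrogen-bond donor, and both steps away from the 2-hydroxyethyl group that are known, a 5.6-fold lower number from compound 1 to compound 2 (0.75 log units; beyond the scatter) reversed and a 46-fold higher number from compound 2 to compound 3 (1.66 log units; beyond the scatter), gave higher numbers. A modest rise is therefore expected, as a 7.9-fold higher number from compound 2 to compound 4 (0.90 log units; beyond the scatter). Compound 4 is estimated at 150 nM, with a range from 40 nM to 600 nM.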

Compound 4, half-maximal inhibitory concentration: 92 nM
The estimate for compound 4 lay 1.6-fold (0.21 log units) above the measured number; the range from low to high includes it.
By their numbers in this assay, from the lowest: compound 2; then compounds 4 and 1 (each within the scatter of the next); then compound 3.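

At this position, the step of a 1.2-fold lower number from compound 1 to compound 4 (0.06 log units; within the scatter) places a group with 0 hydrogen-bond donors level with the hydroxy compound in this assay, so hydrogen-bond donor count alone does not sort these compounds. The step of a 4.8-fold higher number from compound 2 to compound 4 (0.69 log units; beyond the scatter) shows that the entering group does not match the 2-hydroxyethyl group, and compound 2 keeps the lowest number of the four. Nothing at hand explains why these groups give these numbers.

The compounds shown do not separate the role of the chain in compound 2 from that of its terminal hydroxy group. A 2-methoxyethyl group, a longer 3-hydroxypropyl chain or a 2-aminoethyl group on the same saturated ring carbon would bear on that question.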